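The compounds below may be only part of what the source reports. "The series", "measured", "known", "first", "only" and "open" are said of these compounds alone.

Measured compounds:
compound 1, `O=[N+]([O-])c1cccc(CSc2nnc(-c3ccncc3)n2-c2ccccc2)c1`: 22000 nM
compound 2, `O=[N+]([O-])c1ccc(CSc2nnc(-c3ccncc3)n2-c2ccccc2)cc1`: > 50000 nM
compound 3, `O=C(CSc1nnc(-c2ccncc2)n1-c1ccccc1)N/N=C/c1ccc(O)cc1`: > 50000 nM

All three share the core of compound 1 and differ in the group attached to its sulfur-bound carbon or to the carbon with a double bond to nitrogen. In a functional assay on HepG2 cells (Homo sapiens) for inhibition, read by MTT assay, with a stated time of 48 h (a higher number here means a weaker inhibitor, a lower number a stronger inhibitor), compound 1 gives 22000 nM. Compound 2 gives > 50000 nM, which is a limit of the assay rather than a number. The step of an at least 2.2-fold higher number from compound 1 to compound 2 (0.35 log units; beyond the scatter) is therefore only a lower bound on how much weaker compound 2 is. Compound 3 likewise gives > 50000 nM, again a limit. Two of the three values shown sit at the limit of > 50000 nM in this assay, at which 2 of the 3 values shown sit, so compound 3 stands among the weakest inhibitors here, with no finite number to place it.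

Compound 4, `O=C(CSc1nnc(-c2ccncc2)n1-c1ccccc1)N/N=C/c1ccccc1F`, differs from compound 3 in one place: 2-fluorophenyl in place of 4-hydroxyphenyl on a carbon with a double bond to nitrogen. Within the data shown here, no measured step concerns this part of the molecule; the one measured step, an at least 2.2-fold higher number from compound 1 to compound 2 (0.35 log units; beyond the scatter), concerns the group on the sulfur-bound carbon and says nothing about the hydrazone end. With compound 3 at a limit, there is no basis to expect a step beyond the scatter in either direction. Compound 4 is therefore expected to give about 50000 nM in this assay, within 15000 nM to 150000 nM. The expected step of a number no higher from compound 3 to compound 4 (the limit leaves the size open) is essentially none, and a further limit is the most likely outcome.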

Compound 4, half-maximal inhibitory concentration: 15200 nM
For compound 4 the middle estimate is 3.3-fold (0.52 log units) above the measured one, and the stated range covers the measured number.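

Among these compounds, this is the first sign that the group on the carbon with a double bond to nitrogen matters in this assay: 2-fluorophenyl in place of 4-hydroxyphenyl gives an at least 3.2-fold lower number from compound 3 to compound 4 (0.51 log units; beyond the scatter). The two groups are close in size, both with 7 heavy atoms and one six-membered aromatic ring of carbon only, yet 4-hydroxyphenyl has 1 hydrogen-bond donor and 1 hydrogen-bond acceptor while 2-fluorophenyl has 0 of each, so a swap that leaves the atom count unchanged is enough to produce a step beyond the scatter. The result for compound 3 is a limit and not a number, which leaves the step open-ended and means the true difference could be larger: the limit of > 50000 nM in this assay, at which 2 of the 4 values shown sit.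

In this pair the hydroxyl group leaves and the fluorine enters at once, and the ring position changes too, so the compounds shown cannot say which of these changes matters. They also leave open where a plain phenyl ring, or a phenyl ring carrying an amine, would fall in this assay relative to compound 3 and compound 4.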